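Methoxy added to compound 3: notes on the series

The source may report more compounds than this note shows. Statements on the series, on what has been measured and on what is new or still open speak of the compounds shown alone.

Compound 1 `COc1ccc(-c2nc3sc(-c4ccccc4)cn3n2)cc1`: 65%
Compound 2 `COc1cc(-c2nc3sc(-c4ccccc4)cn3n2)cc(OC)c1OC`: 18%
Compound 3 `Clc1ccc(-c2cn3nc(-c4ccccc4)nc3s2)cc1`: 37%

In a functional assay on NCI-H460 cells (Homo sapiens) for inhibition, read by sulforhodamine B assay, with a stated time of 48 h, tested at 10 uM (on this read-out lower numbers stand for less inhibition of growth and higher numbers for more inhibition of growth at the one concentration tested), compound 3 stands in the middle of the three with 37%, above compound 2 and below compound 1, both gaps beyond the scatter. Compound 4 (`COc1ccc(-c2nc3sc(-c4ccc(Cl)cc4)cn3n2)cc1`) differs from compound 3 by one change: methoxy in place of hydrogen on an aromatic carbon, with methoxy in place of hydrogen on an aromatic carbon, para to a large group. Among the measured compounds shown here, no measured pair shows this change alone. Methoxy is present in compound 1 at 65%, but compound 2, which also carries methoxy, goes against any simple trend at 18%. The estimated step is a number 15 percentage points higher from compound 3 to compound 4 (beyond the scatter), an expected rise beyond the scatter, with wide uncertainty. For compound 4 the expected value is 52%, with an estimated range of 28% to 75%.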

Compound 4, percent growth inhibition at one concentration: -39%
Beside the measured number, compound 4's estimate is 91 percentage points above it, and the stated range ends above it.
By their numbers in this assay, from the lowest: compound 4; then compound 2; then compound 3; then compound 1.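

In this assay, methoxy in place of hydrogen on an aromatic carbon gives a number 76 percentage points lower from compound 3 to compound 4 (beyond the scatter), and chloro in place of hydrogen on an aromatic carbon gives a number 104 percentage points lower from compound 1 to compound 4 (beyond the scatter). Among the compounds shown here, both steps run downward, so with these two groups together, each addition lowers the number, which the earlier compounds could not show. No measurement at hand explains this drop. As far as these compounds go, since compound 4 alone carries both groups, it remains open whether an amine or a hydroxyl group in place of methoxy, with chloro kept, would lower the number as well.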